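Removing the hydroxyethyl group from compound 1

This account rests on a few compounds, and the source may have more. Where it says the series, first, only, none or still open, it means among the compounds named here.

Measured so far:
compound 1, `CC(Sc1nc2c(cnn2C)c(=O)n1-c1ccc(CCO)cc1)c1ccccc1` — 3000 nM
compound 2, `CC(Sc1nc2nn(C3COC3)cc2c(=O)n1-c1ccccc1)c1ccccn1` — 480 nM

In an assay on isolated protein for inhibition of Retinaldehyde dehydrogenase 3 (Homo sapiens) (a higher number here means a weaker inhibitor, a lower number a stronger inhibitor), compound 1 gives the highest of the two numbers; compound 2 gives the lower one, and the gap between them lies beyond the usual scatter. The two compounds differ in several places, so no single step can be read from them. Compound 3, `CC(Sc1nc2c(cnn2C)c(=O)n1-c1ccccc1)c1ccccc1`, follows from compound 1 by one change: hydrogen in place of 2-hydroxyethyl on an aromatic carbon. For the measured compounds named here, with no comparable step measured, the expected change in this assay is small, within the scatter or a little toward a lower number. Compound 3 is estimated at 2000 nM (range 700 nM to 6000 nM), an expected step of a 1.5-fold lower number from compound 1 to compound 3 (0.18 log units; within the scatter).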

Compound 3, half-maximal inhibitory concentration: 73 nM
Estimate against measurement, compound 3: 27-fold (1.44 log units) above; measured number below the stated range.
By their numbers in this assay, from the lowest: compound 3; then compound 2; then compound 1.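

In this assay, going from 4-(2-hydroxyethyl)phenyl to phenyl gives a 41-fold lower number from compound 1 to compound 3 (1.61 log units; beyond the scatter) and so shows that this position strongly affects the number. The substituent here is far from a neutral passenger, and the unsubstituted phenyl is much preferred to the 2-hydroxyethyl version. Nothing measured here explains the size of this step. On these data alone, whether the loss comes from the hydroxyl or from the chain that carries it stays open. An ethyl or a methoxy group at this position would help separate the two, as would a small fluorine atom.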